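Replacing 2-carboxyethenyl on the shared core

The compounds below may be only part of what the source reports. "The series", "measured", "known", "first", "only" and "open" are said of these compounds alone.

In a functional assay with Oryctolagus cuniculus as the target (a lower number here means a stronger inhibitor, a higher number a weaker inhibitor), compound 1 `COc1ccc(-c2nc(CNC(=O)N3CCOCC3)sc2-c2ccc(OC)cc2)cc1` gives 660 nM. Compound 2 `COc1ccc(-c2nc(/C=C/C(=O)O)sc2-c2ccc(OC)cc2)cc1` gives > 100 nM, which is a limit and not a number. Among the compounds with values here, the only measured step, a step that the limit leaves unreadable from compound 1 to compound 2, offers neither a size nor a direction to carry forward. Compound 3 `COc1ccc(-c2nc(C3=NNC(=O)CC3)sc2-c2ccc(OC)cc2)cc1` differs from compound 2 as follows: a group of 7 heavy atoms (4 carbon, 2 nitrogen, 1 oxygen; one six-membered non-aromatic ring with 2 hetero atoms) in place of a group of 5 heavy atoms (3 carbon, 2 oxygen; no ring), on an aromatic carbon. Within the data shown here, compound 1 at 660 nM is the only true number to lean on, so the expected change, a step that the limit leaves unreadable from compound 2 to compound 3, is a rough estimate with its direction left open. For compound 3 the estimated value is 300 nM, with an expected range of 40 nM to 2000 nM.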

Compound 3, half-maximal inhibitory concentration: > 1000 nM
Compound 3: only a limit was reported (the forecaster's own chance of this, stated with the estimate: 35%); at least 3.3-fold (0.52 log units) between middle value and limit.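

In this assay compound 3 gives > 1000 nM, which is a limit and not a number. Set against the (((morpholin-4-yl)carbonyl)amino)methyl group, this six-membered non-aromatic ring gives the first readable step at this aromatic carbon, an at least 1.5-fold higher number from compound 1 to compound 3 (0.18 log units; that floor lies within the scatter), though that floor alone does not establish a real loss. The step between the two compounds that carry only limits cannot be read.

Going by these compounds, how far compound 3 lies past its limit remains open. So does what a primary amine or a longer carbon chain would give on this aromatic carbon.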